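A few compounds are considered here, and "the series" means these few. Any claim that something is new, unique, unknown or untested is made for them only; others in the source may bear on it.

Compound 1 `c1ccc(Nc2ccc3ccccc3n2)nc1` and compound 2 `Clc1ccnc(Nc2ccc3ccccc3n2)c1` share one core, while compound 3 `Oc1cccc2ccc(Oc3ccccn3)nc12` and compound 4 `Oc1ccc(Cl)c2ccc(Oc3ccccn3)nc12` share another. How the core of compound 1 and the core of compound 3 differ is not broken down here. In a functional assay on PC-3 cells (Homo sapiens) for antiproliferative activity, read by MTT assay, with a stated time of 96 h (on this read-out higher numbers stand for weaker inhibition of growth and lower numbers for stronger inhibition of growth), compound 1 gives > 30000 nM, which is a limit of the assay and not a number. In this assay compound 2 gives > 30000 nM, likewise a limit. The change from compound 1 to compound 2 is chloro in place of hydrogen on an aromatic carbon, and the step that the two limits leave unreadable from compound 1 to compound 2 cannot be read because both values sit at the limit of > 30000 nM in this assay, at which 3 of the 3 values shown sit. In this assay compound 3 gives > 30000 nM, again a limit. The change from compound 3 to compound 4 is chloro in place of hydrogen on an aromatic carbon: the same kind of change as from compound 1 to compound 2, but here the chloro sits on a six-membered aromatic ring of carbon only, part of a fused or bridged system of two rings, ortho to a fused ring, meta to a fused ring and para to a hydroxy group, whereas in compound 2 it sits on a six-membered aromatic ring with 1 nitrogen, meta to a large group and opposite the ring nitrogen. Compound 4 has not yet been measured in this assay. Compound 4 is expected to show the step that the limit leaves unreadable from compound 3 to compound 4 because all three values shown sit at the limit of > 30000 nM in this assay, at which 3 of the 3 values shown sit. Compound 4 is expected to give about 40000 nM in this assay, most likely reported once more as a limit, somewhere between 15000 nM and 120000 nM.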

Compound 4, concentration for 50% growth inhibition: > 30000 nM
Compound 4: no number, only a limit; the forecaster's own chance of this, stated with the estimate: 85%; the middle value lies beyond the limit too.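

In this assay no step can be read from compound 3 to compound 4, because both values are limits of the assay and not numbers: the limit of > 30000 nM in this assay, at which 4 of the 4 values shown sit.

The compounds shown leave open whether chloro in place of hydrogen on an aromatic carbon changes growth inhibition on either core, and how the core of compound 1 and the core of compound 3 compare.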